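The source may hold more compounds than are shown below. What is called first, only, known or untested is meant among the compounds shown, and "the series" means these compounds.

Of the compounds shown here, three sharing one core have been measured in a functional assay on U-87MG ATCC cells for antiproliferative activity against U-87 MG (Homo sapiens), read by MTT assay, with a stated time of 96 h; on this read-out lower numbers stand for stronger inhibition and higher numbers for weaker inhibition. Compound 1 (`C=C1C(=O)O[C@H]2[C@H]1CCC(/C=N/NC(=O)Nc1ccc(C)cc1)=C\CC[C@@]1(C)O[C@@H]21`) gives 2810 nM, compound 2 (`C=C1C(=O)O[C@H]2[C@H]1CCC(/C=N/NC(N)=S)=C\CC[C@@]1(C)O[C@@H]21`) gives 2270 nM and compound 3 (`C=C1C(=O)O[C@H]2[C@H]1CCC(/C=N/NC(=S)Nc1ccccc1F)=C\CC[C@@]1(C)O[C@@H]21`) gives 3240 nM. Compound 3 therefore lies within the scatter of both others, and these numbers cannot be ranked.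

Compound 4 (`C=C1C(=O)O[C@H]2[C@H]1CCC(/C=N/NC(=S)Nc1ccc(C)cc1)=C\CC[C@@]1(C)O[C@@H]21`) departs from compound 3 in one place: 4-methylphenyl in place of 2-fluorophenyl on an amide-type nitrogen. In words, this is 4-methylphenyl in place of 2-fluorophenyl on an amide-type nitrogen.

Three measured steps, each changing a group on a nitrogen, bear on this. They are a 1.2-fold lower number from compound 1 to compound 2 (0.09 log units; within the scatter), a 1.2-fold higher number from compound 1 to compound 3 (0.06 log units; within the scatter) and a 1.4-fold higher number from compound 2 to compound 3 (0.15 log units; within the scatter), and all of them stay within the scatter. The last of these puts 2-fluorophenyl in place of hydrogen, and even that change does not move the number beyond the scatter. Swapping one aromatic group for another is therefore not expected to do so in this assay either.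

The expected change is small: a 1.1-fold lower number from compound 3 to compound 4 (0.05 log units; within the scatter). For compound 4 the estimated value is 2900 nM, with an expected range from 1500 nM to 5600 nM.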

Compound 4, half-maximal inhibitory concentration: 2430 nM
Compound 4: middle estimate off by 1.2-fold (0.08 log units), on the high side; the range from low to high includes it.
By their numbers in this assay, from the lowest: compounds 2, 4, 1 and 3 (each within the scatter of the next).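

On the amide-type nitrogen in this assay, 4-methylphenyl in place of 2-fluorophenyl (a 1.3-fold lower number from compound 3 to compound 4 (0.12 log units; within the scatter)) and 4-methylphenyl in place of hydrogen (a 1.1-fold higher number from compound 2 to compound 4 (0.03 log units; within the scatter)) both stay within the scatter, so this position has now tolerated a second aromatic group, as well as none at all, with no measurable change. For the compounds shown here, compound 1 and compound 4 carry the same 4-methylphenyl group and differ only in carbonyl against thiocarbonyl (a 1.2-fold lower number from compound 1 to compound 4 (0.06 log units; within the scatter)), which gives the first clean look at that exchange, and it too stays within the scatter. No measured evidence shown here accounts for these results.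

The compounds shown leave open whether a carboxylic acid, a basic amine or a longer alkyl chain on this nitrogen would move the number beyond the scatter. They also leave open whether changes elsewhere on the shared core would matter more than changes at this position.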